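The compounds below may be only part of what the source reports. "The series", "measured", "known", "first", "only" and "open" are said of these compounds alone.

Measured so far:
Compound 1 `COC(=O)c1cc(C[C@@H](C)CN2C[C@@H]3CCCC[C@@H]3[C@H](C(=O)N3CCN(c4ccc([N+](=O)[O-])cc4)CC3)C2)cc(C(=O)OC)c1` — in an assay on isolated protein for binding affinity to somatostatin receptor type 3 (Homo sapiens) (a higher number here means weaker binding, a lower number tighter binding), compound 1 gives 2.24 nM.
Compound 2 `Cc1nc2cc(C[C@H](C)CN3C[C@@H]4CCCC[C@@H]4[C@H](C(=O)N4CCN(c5ccc(F)c(F)c5)CC4)C3)ccc2o1` — in this assay compound 2 gives 3.39 nM.

Among the measured compounds shown here, compound 2 stands at one of only two numbers available, and its value and that of compound 1 lie within the usual scatter of each other, so the two cannot be separated on these data. For the measured compounds named here, the two differ in several places at once, so no single-point step is known.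

Compound 3 `Cc1cn2cc(C[C@H](C)CN3C[C@@H]4CCCC[C@@H]4[C@H](C(=O)N4CCN(c5ccc(F)c(F)c5)CC4)C3)ccc2n1` is the unmeasured analogue of compound 2, differing by a group of 10 heavy atoms (8 carbon, 2 nitrogen; one five-membered aromatic ring with 2 hetero atoms, one six-membered aromatic ring with 1 hetero atom) in place of a group of 10 heavy atoms (8 carbon, 1 nitrogen, 1 oxygen; one five-membered aromatic ring with 2 hetero atoms, one six-membered aromatic ring of carbon only), on a saturated chain carbon, three bonds along the chain from an amine nitrogen in a ring. The swap keeps the size of the group and its count of hydrogen-bond acceptors, and the rest of the molecule is unchanged. Going by the values given here, with no comparable step measured, the expected step in this assay is small, plausibly none beyond the scatter, with a slight lean toward a weaker number. Compound 3 is therefore estimated at 4.5 nM, with a range of 1.5 nM to 14 nM, which corresponds to an expected 1.3-fold higher number from compound 2 to compound 3 (0.12 log units; within the scatter).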

Compound 3, dissociation constant: 107 nM
Beside the measured number, compound 3's estimate is 24-fold (1.38 log units) below it; measured number outside the range, above it.
By their numbers in this assay, from the lowest: compounds 1 and 2 (each within the scatter of the next); then compound 3.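

In this assay, this position on a saturated chain carbon, three bonds along the chain from an amine nitrogen in a ring, proves sensitive to the identity of the group it carries: replacing 2-methyl-1,3-benzoxazol-5-yl with the nitrogen-containing group gives a 32-fold higher number from compound 2 to compound 3 (1.50 log units; beyond the scatter). The two groups match in heavy-atom count, hydrogen-bond donors and acceptors, and net charge, so these shared counts alone do not preserve the binding seen for compound 2. No available evidence bears on the origin of this loss.

The compounds shown leave open which part of the change carries the step, the nitrogen in the six-membered ring or the altered five-membered ring. They also leave open how the position would respond to a sulfur atom in place of the oxygen of the 2-methyl-1,3-benzoxazol-5-yl group.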